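This account rests on a few compounds, and the source may have more. Where it says the series, first, only, none or still open, it means among the compounds named here.

Of the compounds shown here, three built on one shared core have so far been measured in a functional assay on A549 cells (Homo sapiens) for inhibition, read by sulforhodamine B assay, with a stated time of 48 h, tested at 50 uM; a higher number here means more inhibition of growth at the concentration tested, a lower number less inhibition of growth. Compound 1 `COc1ccc([C@@H]2C/C(=N/OCc3cn(-c4cccc(CO)c4)nn3)c3cc(CC=C(C)C)c(OC)cc3O2)cc1` gives 43% in this assay, and compound 2 `COc1ccc([C@@H]2C/C(=N/OCc3cn(-c4ccc(C#N)cc4)nn3)c3cc(CC=C(C)C)c(OC)cc3O2)cc1` gives 42%. Compound 3 `COc1ccc([C@@H]2C/C(=N/OCc3cn(-c4ccc(NC(=O)c5ccccc5)cc4)nn3)c3cc(CC=C(C)C)c(OC)cc3O2)cc1` gives 31%, the lowest of the three numbers, and its gaps to both other compounds are beyond the scatter; the nearer one is a number 11 percentage points lower from compound 2 to compound 3 (beyond the scatter). The earlier step, a number 1 percentage points lower from compound 1 to compound 2 (within the scatter), shows that exchanging one substituent on the aromatic nitrogen for another made no difference that can be trusted, whereas adding benzamido in place of cyano cost a modest amount.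

Compound 4 `COc1ccc([C@@H]2C/C(=N/OCc3cn(-c4ccc(NC(C)=O)cc4)nn3)c3cc(CC=C(C)C)c(OC)cc3O2)cc1` has not yet been measured. It differs from compound 3 in a single place: methyl in place of phenyl on a carbonyl carbon. Among the compounds with values here, no measured step repeats this exact change. Within the data shown here, the only step that touches the amide is a number 11 percentage points lower from compound 2 to compound 3 (beyond the scatter), where the whole benzamido group arrived and the number fell modestly. Whether trimming that group back to acetamido recovers part of that loss cannot be read from two steps alone. The expectation is therefore a small step, a number 5 percentage points higher from compound 3 to compound 4 (within the scatter), toward the value of compound 2, held with wide uncertainty. Compound 4 is expected to give about 36% in this assay, within a range of 22% to 50%.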

Compound 4, percent growth inhibition at one concentration: 19%
Compound 4: the middle estimate sits 17 percentage points above what was measured; measured number outside the range, below it.
By their numbers in this assay, from the lowest: compound 4; then compound 3; then compounds 2 and 1 (each within the scatter of the next).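

Trimming benzamido to acetamido moved the number away from that of the cyano compound, not toward it: in this assay the step is a number 12 percentage points lower from compound 3 to compound 4 (beyond the scatter), so at this carbonyl carbon, phenyl goes with more growth inhibition than methyl. The amide at this place therefore need not cost the same whatever it carries, since the step with benzamido in place of cyano is a number 11 percentage points lower from compound 2 to compound 3 (beyond the scatter), while the step with acetamido in place of cyano is larger, a number 23 percentage points lower from compound 2 to compound 4 (beyond the scatter), and the step with 4-acetamidophenyl in place of 3-(hydroxymethyl)phenyl is a number 24 percentage points lower from compound 1 to compound 4 (beyond the scatter). No measurement is available that explains why the phenyl and methyl amides differ in this way.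

With only phenyl and methyl shown on the carbonyl carbon, two groups cannot show whether the number follows the size of the group or something particular to phenyl, and a longer chain such as propyl or a cyclohexyl ring could separate the two. On these data alone, it also remains open how a free amine in place of the whole amide on the aromatic ring would compare with these amides and with the cyano compound.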